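This account rests on a few compounds, and the source may have more. Where it says the series, first, only, none or still open, it means among the compounds named here.

In a functional assay on A549 cells (Homo sapiens) for inhibition, read by MTT assay, with a stated time of 72 h (on this read-out higher numbers stand for weaker inhibition and lower numbers for stronger inhibition), compound 1 `CC(C)(C)n1cc2c(n1)C(=O)CC1(CCN(C(=O)c3cc(-c4ccccc4)nc4ccccc34)CC1)O2` gives 1940 nM and compound 2 `Cc1ccc(-c2cc(C(=O)N3CCC4(CC3)CC(=O)c3nn(C(C)(C)C)cc3O4)c3ccccc3n2)cc1` gives 5300 nM, so compound 2 holds the higher of the two numbers and is the weaker inhibitor. Compound 3 `Cc1ccccc1-c1cc(C(=O)N2CCC3(CC2)CC(=O)c2nn(C(C)(C)C)cc2O3)c2ccccc2n1` has not yet been measured. It differs from compound 2 by one change: 2-methylphenyl in place of 4-methylphenyl on an aromatic carbon. Going by the values given here, only one measured step bears on this, a 2.7-fold higher number from compound 1 to compound 2 (0.44 log units; beyond the scatter), a modest rise that came with a methyl in place of hydrogen on an aromatic carbon. Among the compounds with values here, no measured compound shows what the same methyl does at the new place, so that step only sets the likely scale. A slight fall is expected, not a step beyond the scatter, and the estimated change is a 1.3-fold lower number from compound 2 to compound 3 (0.12 log units; within the scatter). In this assay, compound 3 is estimated at 4000 nM, with an expected range from 1600 nM to 10000 nM.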

Compound 3, half-maximal inhibitory concentration: 1880 nM
Estimate against measurement, compound 3: 2.1-fold (0.33 log units) above; measured number inside the range.
By their numbers in this assay, from the lowest: compounds 3 and 1 (each within the scatter of the next); then compound 2.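

In this assay, moving the methyl from 4-methylphenyl to 2-methylphenyl gives a 2.8-fold lower number from compound 2 to compound 3 (0.45 log units; beyond the scatter), so at this position, on the aromatic carbon next to the ring nitrogen, the result depends on where the methyl sits on the phenyl group and not only on its presence. Set against the plain phenyl group, 2-methylphenyl gives a 1.0-fold lower number from compound 1 to compound 3 (0.01 log units; within the scatter), so the rise seen with the 4-methylphenyl group of compound 2 does not appear with compound 3, and among these compounds only the 4-methylphenyl group separates from the rest. Nothing available explains this difference between the two methylphenyl groups.

From the compounds shown here alone, whether a methoxy group, a chlorine or an ethyl group on the phenyl ring would follow compound 3 or compound 2 stays open. So does the effect of an amine or a carboxylic acid there.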